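Trifluoromethyl added to the benzyl ring of compound 3

The source may report more compounds than this note shows. Statements on the series, on what has been measured and on what is new or still open speak of the compounds shown alone.

Three compounds of the series have numbers in a functional assay on HT-29 cells (Homo sapiens) for inhibition, read by MTT assay, with a stated time of 48 h; on this read-out higher numbers stand for weaker inhibition and lower numbers for stronger inhibition. Compound 1 `O=C(NC(=S)Nc1ccc(Cl)c(-c2nc3ccccc3[nH]2)c1)c1ccc(OCc2ccc(C(F)(F)F)cc2)cc1` gives 12900 nM; compound 2 `O=C(NC(=S)Nc1ccc(Cl)c(-c2nc3ccccc3[nH]2)c1)c1ccc(OCc2ccc(Cl)c(Cl)c2)cc1` gives 4930 nM; compound 3 `Cc1ccc(NC(=O)NC(=O)c2ccc(OCc3ccccc3)cc2)cc1-c1nc2ccccc2[nH]1` gives 16400 nM. Compound 3 stands highest of the three: its gap to compound 1 lies within the scatter, its gap to compound 2 beyond it. Going by the values given here, the one step measured so far, a 2.6-fold lower number from compound 1 to compound 2 (0.42 log units; beyond the scatter), swaps one substituted benzyl ring for another.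

Compound 4 `Cc1ccc(NC(=O)NC(=O)c2ccc(OCc3cccc(C(F)(F)F)c3)cc2)cc1-c1nc2ccccc2[nH]1` differs from compound 3 by trifluoromethyl in place of hydrogen on an aromatic carbon, sitting meta to a large group; read one bond further out, phenyl becomes 3-(trifluoromethyl)phenyl. Among the compounds with values here, no measured pair adds a trifluoromethyl to a bare benzyl ring, so the step from compound 1 to compound 2 bears on it only loosely, showing that exchanging substituents on that ring moves this assay by a modest amount. On that basis compound 4 is expected to stay close to compound 3, with at most a small shift in either direction, a 1.4-fold lower number from compound 3 to compound 4 (0.14 log units; within the scatter). The estimate for compound 4 in this assay is 12000 nM, within a range from 5000 nM to 30000 nM.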

Compound 4, half-maximal inhibitory concentration: 3520 nM
Estimate against measurement, compound 4: 3.4-fold (0.53 log units) above; measured number below the stated range.
By their numbers in this assay, from the lowest: compounds 4 and 2 (each within the scatter of the next); then compounds 1 and 3 (each within the scatter of the next).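

In this assay, the addition of trifluoromethyl to the unsubstituted benzyl ring gives a 4.7-fold lower number from compound 3 to compound 4 (0.67 log units; beyond the scatter). The earlier step, a 2.6-fold lower number from compound 1 to compound 2 (0.42 log units; beyond the scatter), only exchanged one substituted benzyl ring for another, whereas this pair starts from the bare ring and shows that a single group on an aromatic carbon, meta to a large group, is enough to move the number beyond the scatter. Nothing measured on these compounds accounts for the step.

On these data alone, whether this shift belongs to trifluoromethyl itself or would also follow from another group on the same carbon, such as a nitrile, a methoxy group or a single chlorine, remains open. Compound 1 also carries trifluoromethyl on its benzyl ring but differs from compound 4 in more than one place, so the compounds shown do not tell how the result depends on where the group sits on that ring.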